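Swapping a chlorophenyl for a methylphenyl in liver cell tolerance

This account rests on a few compounds, and the source may have more. Where it says the series, first, only, none or still open, it means among the compounds named here.

Three sugar-bearing compounds were tested in an ADME assay on HepG2 cells (Homo sapiens) for cytotoxicity, read by MTT assay, with a stated time of 48 h; a higher number here means that more compound is tolerated, a lower number that less compound is tolerated. Compound 1 `CC(=O)OC[C@H]1O[C@H](OC[C@H](Cn2cc(COc3ccc(-c4noc(NC5CCCCC5)n4)cc3)nn2)OC(C)=O)C=C[C@@H]1OC(C)=O` gives 99.5 ug/mL. Compound 2 `CC(=O)OC[C@H]1O[C@H](OC[C@H](Cn2cc(-c3ccc(-c4noc(NC5CCCCC5)n4)cc3)nn2)OC(C)=O)C=C[C@@H]1OC(C)=O` gives 79.8 ug/mL. Compound 3 `CC(=O)OC[C@H]1O[C@H](OC[C@@H](Cn2cc(CN(c3nc(-c4ccc(Cl)cc4)no3)C3CCCCC3)nn2)OC(C)=O)C=C[C@@H]1OC(C)=O` gives 46.9 ug/mL, the lowest of the three numbers. The gap between compound 3 and compound 2 lies within the scatter of repeated measurements, so no order can be read between those two; the gap between compound 3 and compound 1 lies beyond the scatter, so compound 1 is tolerated at a higher concentration than compound 3.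

Compound 4 `CC(=O)OC[C@H]1O[C@H](OC[C@@H](Cn2cc(CN(c3nc(-c4cccc(C)c4)no3)C3CCCCC3)nn2)OC(C)=O)C=C[C@@H]1OC(C)=O` has not yet been measured. It differs from compound 3 in one place: 3-methylphenyl in place of 4-chlorophenyl on an aromatic carbon. The aromatic ring stays where it was; only the group attached to it changes. For the measured compounds named here, no measured pair shows a change of this kind, so there is no precedent to lean on. The step from compound 3 to compound 4 is expected to be small, most likely none beyond the scatter, as a 1.1-fold higher number from compound 3 to compound 4 (0.03 log units; within the scatter). Compound 4 is estimated at 50 ug/mL in this assay, with a range from 25 ug/mL to 100 ug/mL.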

Compound 4, half-maximal cytotoxic concentration: 39.2 ug/mL
Compound 4: the middle estimate sits 1.3-fold (0.11 log units) above what was measured, and the stated range covers the measured number.
By their numbers in this assay, from the lowest: compounds 4, 3, 2 and 1 (each within the scatter of the next, the first and the last beyond it).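

For the compounds shown here, this is the first pair here that differs in one place, so it gives the first direct reading of the group on an aromatic carbon of the five-membered aromatic ring with 2 nitrogen and 1 oxygen. In this assay, 3-methylphenyl in place of 4-chlorophenyl gives a 1.2-fold lower number from compound 3 to compound 4 (0.08 log units; within the scatter), so this exchange leaves no readable mark on how much compound the cells tolerate. Nothing available bears on why the two groups read alike.

The exchange alters both the substituent and its place on the phenyl ring, so 4-methylphenyl or 3-chlorophenyl would be needed to tell those two changes apart. On these data alone, whether the position stays this undemanding with a plain phenyl ring, or with a phenyl ring carrying an amine or a carboxylic acid, remains open.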